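The source may report more compounds than this note shows. Statements on the series, on what has been measured and on what is new or still open speak of the compounds shown alone.

Measured compounds:

- Compound 1, `COCC1c2c(-c3ccncc3)c(-c3cccc(C)n3)nn2CC1(C)C`: in a functional assay on MCF7 cells (Homo sapiens) for cytotoxicity, with a stated time of 72 h (a higher number here means a weaker inhibitor, a lower number a stronger inhibitor), compound 1 gives only the limit > 100000 nM.
- Compound 2, `Cc1cc(-c2c(-c3cccc(C)n3)nn3c2C(C)C(C)(C)C3)ccn1`: in this assay compound 2 gives only the limit > 100000 nM.
- Compound 3, `CCc1cccc(-c2nn3c(c2-c2ccncc2)C(C)C(C)(C)C3)n1`: in this assay compound 3 gives only the limit > 100000 nM.

None of the three compounds reached a measurable concentration: all sit at the limit of > 100000 nM in this assay, at which 3 of the 3 values shown sit. Compound 3 therefore stands exactly where compound 1 and compound 2 stand, at the edge of what the assay can report, and no number places it above or below them.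

Compound 4, `Cc1cccc(-c2nn3c(c2-c2ccncc2)C(C)C(C)(C)C3)n1`, is the next compound to be tested. Compared with compound 3 it carries one change, (hydrogen in place of methyl on a saturated chain carbon bound to an aromatic carbon). Seen one bond further out, the ethyl becomes a methyl, so the 6-ethylpyridin-2-yl group of compound 3 becomes a 6-methylpyridin-2-yl group.

Within the data shown here, no pair of measured compounds shows this kind of change, so there is no measured step to lean on. Since compound 3 gives only a limit, the change can only be expected to stay within the scatter, and compound 4 is expected to remain at the limit as well. The expected step from compound 3 to compound 4 is a number no higher from compound 3 to compound 4 (the limit leaves the size open), essentially none. For compound 4 the estimate in this assay is 100000 nM, within 30000 nM to 300000 nM.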

Compound 4, half-maximal inhibitory concentration: > 100000 nM
Compound 4: only a limit was reported; the forecaster's own chance of this, stated with the estimate: 85%; the middle value lies on the limit itself.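

In this assay, compound 4 gives only a limit, as do compound 1, compound 2 and compound 3, so the steps from those three to compound 4 cannot be read and no new step emerges: the limit of > 100000 nM in this assay, at which 4 of the 4 values shown sit.

The compounds shown leave open how strong any of the four really is, and whether changing ethyl to methyl makes any difference.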